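From 4-methoxyphenyl to thiophen-2-yl at an assay limit

A few compounds are considered here, and "the series" means these few. Any claim that something is new, unique, unknown or untested is made for them only; others in the source may bear on it.

Two compounds sharing one core, compound 1 (`O=C(Nc1ccc(Nc2ncnc3c2OCCN3)cc1)Nc1ccc(Cl)c(C(F)(F)F)c1`) and compound 2 (`COc1ccc(NC(=O)Nc2ccc(Nc3ncnc4c3OCCN4)cc2)cc1`), have been tested in a functional assay on BaF3 cells (Mus musculus) for inhibition, read by MTT assay, with a stated time of 3 days (a lower number here means a stronger inhibitor of growth, a higher number a weaker inhibitor of growth), so far. Compound 1 gives > 10000 nM as a limit and not a number. Compound 2 gives > 10000 nM as a limit too. Compound 2 therefore has no exact value, and the two compounds cannot be ranked against each other. Compound 3 (`O=C(Nc1ccc(Nc2ncnc3c2OCCN3)cc1)Nc1cccs1`) carries thiophen-2-yl in place of 4-methoxyphenyl on an amide-type nitrogen, and thiophen-2-yl in place of 4-methoxyphenyl on an amide-type nitrogen sums up that change. Among the measured compounds shown here, no measured pair shows what a change at this place does. For the measured compounds named here, the only guide is the limit of > 10000 nM in this assay, at which 2 of the 2 values shown sit, and it offers no exact number to build on. The expected step of a number no higher from compound 2 to compound 3 (the limit leaves the size open) stays within the usual scatter, with no direction foreseen. For compound 3 the estimated value is 10000 nM with an expected range from 3000 nM to 15000 nM as its likely span.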

Compound 3, concentration for 50% growth inhibition: > 10000 nM
Compound 3 was reported as a limit; the forecaster's own chance of this, stated with the estimate: 80%; the middle value sits exactly at the limit.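

In this assay compound 3 gives > 10000 nM, a limit and not a number. Among the compounds shown here, no step from compound 2 to compound 3 can be read, because both results are limits: the limit of > 10000 nM in this assay, at which 3 of the 3 values shown sit. The compounds shown leave open what any change on the amide-type nitrogen does to growth inhibition.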